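Two Methoxy Additions, One Measured and One Awaited

The source may report more compounds than this note shows. Statements on the series, on what has been measured and on what is new or still open speak of the compounds shown alone.

Of the compounds shown here, three have so far been tested in a functional assay on SN12C cells (Homo sapiens) for cytotoxicity, read by sulforhodamine B assay, with a stated time of 48 h, tested at 10 uM; on this read-out lower numbers stand for a stronger effect and higher numbers for a weaker effect at the one concentration tested. Compound 1 `COc1ccc(-c2cc(/C=C/C(=O)c3ccc(N)cc3)[nH]n2)cc1` gives -16% in this assay, while compound 3 `COc1ccc(-c2cc(/C=C/C(=O)c3ccc(N)cc3)[nH]n2)cc1OC` gives 14%. The two differ only by methoxy in place of hydrogen on an aromatic carbon, a change that carries the step of a number 30 percentage points higher from compound 1 to compound 3 (beyond the scatter). Compound 2 `COc1ccc(C(=O)/C=C/c2cc(-c3cc(OC)c(OC)c(OC)c3)n[nH]2)cc1OC` differs from compound 1 in more than one place, and the difference between the two cores is not broken down here. In this assay compound 2 gives -82%, the lowest of the three numbers, with its steps to compound 1 and to compound 3 both beyond the scatter.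

Compound 4 `COc1cc(C(=O)/C=C/c2cc(-c3cc(OC)c(OC)c(OC)c3)n[nH]2)cc(OC)c1OC` remains to be measured. It arises from compound 2 by methoxy in place of hydrogen on an aromatic carbon. Within the data shown here, this is the same kind of change as the one from compound 1 to compound 3, though here the entering group also sits meta to a methoxy group. On the precedent of a number 30 percentage points higher from compound 1 to compound 3 (beyond the scatter), a step of a number 27 percentage points higher from compound 2 to compound 4 (beyond the scatter) is expected in this assay. Compound 4 is therefore estimated at -55% in this assay, with a likely range from -85% to -20%.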

Compound 4, a percentage reported as activity, at one concentration (the size of the read-out at that concentration, not a potency): -86%
Compound 4: the middle estimate sits 31 percentage points above what was measured; measured number outside the range, below it.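

On the core of compound 2, methoxy in place of hydrogen on an aromatic carbon gave a number 4 percentage points lower from compound 2 to compound 4 (within the scatter) in this assay, so this addition leaves no difference that can be read between the two compounds. Set beside the earlier pair, the same change did not carry over from one core to the other at the same size: the same change on two cores in this assay, a number 30 percentage points higher (beyond the scatter) from compound 1 to compound 3 and a number 4 percentage points lower (within the scatter) from compound 2 to compound 4, 34 percentage points apart, beyond the scatter of two such steps This shows that the step seen on the core of compound 1 cannot simply be transferred within this series, but it does not show why the two steps part, and with only one pair per core it cannot separate the effect of the core from that of the place, which in compound 4 is ortho to a methoxy group and meta to a methoxy group.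

The compounds shown leave open whether a hydroxyl group or an ethoxy group at that place on the core of compound 2 would shift the number. They also leave open which of the two steps, if either, a methoxy addition on a third core would follow.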